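This account rests on a few compounds, and the source may have more. Where it says the series, first, only, none or still open, it means among the compounds named here.

Measured so far in an ADME assay on Vero cells (Chlorocebus sabaeus) for cytotoxicity; on this read-out higher numbers stand for lower toxicity in this test and lower numbers for higher toxicity in this test:

compound 1 `O=C(O)c1cccc(-c2ccc(/C=C3\S/C(=N\c4ccccc4)N(c4ccc(Cl)cc4)C3=O)s2)c1` — > 200000 nM
compound 2 `O=C(O)c1cccc(-c2ccc(/C=C3\S/C(=N\c4ccccc4)N(c4cccnc4Cl)C3=O)s2)c1` — > 200000 nM

Both values in this assay are limits, not numbers. For compound 1 the assay gives only a limit, > 200000 nM. For compound 2 the assay likewise gives only a limit, > 200000 nM, so compound 2 stands at the edge of what the test can report, with no number attached. Within the data shown here, the one measured step, a step that the two limits leave unreadable from compound 1 to compound 2, where 2-chloropyridin-3-yl replaces 4-chlorophenyl on an amide-type nitrogen in a ring, cannot be sized, because of the limit of > 200000 nM in this assay, at which 2 of the 2 values shown sit.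

Compound 3 `Cc1ncccc1N1C(=O)/C(=C/c2ccc(-c3cccc(C(=O)O)c3)s2)S/C1=N\c1ccccc1` is the next member, not yet measured. It differs from compound 2 by methyl in place of chloro on an aromatic carbon, read one bond further out as 2-chloropyridin-3-yl to 2-methylpyridin-3-yl. Among the measured compounds shown here, no measured step bears on this exchange; the only evidence is that the closely related compound 2 sits at the limit. The estimated step that the limit leaves unreadable from compound 2 to compound 3 is therefore expected to be none beyond the scatter. Compound 3 is estimated at 250000 nM, with a range from 100000 nM to 600000 nM, most likely again reported only as a limit.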

Compound 3, half-maximal cytotoxic concentration: > 200000 nM
Compound 3: a limit, no number; the forecaster's own chance of this, stated with the estimate: 80%; the middle value lies beyond the limit too.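

In this assay compound 3 gives > 200000 nM, which is a limit and not a number. The steps joining compound 3 to compound 1 and to compound 2 therefore cannot be read, because all three share the same limit: the limit of > 200000 nM in this assay, at which 3 of the 3 values shown sit.

Going by these compounds, whether compound 1, compound 2 and compound 3 differ in toxicity to these cells stays open.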